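Oxazolidinedione to thiazolidinedione: a permeability forecast

The source may hold more compounds than are shown below. What is called first, only, known or untested is meant among the compounds shown, and "the series" means these compounds.

This account follows compound 1 `CC(C)[C@H](C[C@H]1OC(=O)NC1=O)c1ccc(-c2ccc3cccc(F)c3c2)[nH]c1=O` and the change that leads to compound 4 `CC(C)[C@H](C[C@H]1SC(=O)NC1=O)c1ccc(-c2ccc3cccc(F)c3c2)[nH]c1=O`. In an ADME assay on MDCK cells (Canis lupus familiaris) for permeability, in the apical to basolateral direction (a lower number here means that the compound crosses the layer more slowly, a higher number that the compound crosses the layer faster), compound 1 gives 10.3 10^-6 cm/s, the lowest of the two numbers available. Its neighbour compound 2 `CC(C)C(CC1C(=O)NC(=O)N1C)c1ccc(-c2ccc3cccc(F)c3c2)[nH]c1=O` gives 17.6 10^-6 cm/s in this assay, a gap that lies within the usual scatter, so the two are best treated as alike. For compound 3 `CC(C)C1(c2ccc(-c3ccc4ccccc4c3)[nH]c2=O)OC(=O)NC1=O` the entry in this assay reads "not determined" (no result reported), so no number is available for it.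

Compound 4 differs from compound 1 by one exchange: 2,4-dioxo-1,3-thiazolidin-5-yl in place of 2,4-dioxo-1,3-oxazolidin-5-yl on a saturated chain carbon, two bonds along the chain from an aromatic carbon. The thiazolidinedione ring that enters matches the oxazolidinedione it replaces in size, in donors and in acceptors, and no comparison among the measured compounds isolates this swap. Without such a reference the step is expected to be small, either direction, and not beyond the scatter, leaning slightly upward; the step from compound 1 to compound 4 is therefore estimated as a 1.3-fold higher number from compound 1 to compound 4 (0.10 log units; within the scatter). For compound 4 in this assay the expected value is 13 10^-6 cm/s, within a range from 6 10^-6 cm/s to 26 10^-6 cm/s.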

Compound 4, apparent permeability: 17.6 10^-6 cm/s
Estimate against measurement, compound 4: 1.4-fold (0.13 log units) below; measured number inside the range.
By their numbers in this assay, from the lowest: compounds 1, 2 and 4 (each within the scatter of the next).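

With compound 4, this position has its first direct comparison in this assay: 2,4-dioxo-1,3-thiazolidin-5-yl in place of 2,4-dioxo-1,3-oxazolidin-5-yl gives a 1.7-fold higher number from compound 1 to compound 4 (0.23 log units; within the scatter) on a saturated chain carbon, two bonds along the chain from an aromatic carbon. Compound 1 and compound 4 are therefore best read as alike here, and at this place the exchange of the ring oxygen for sulfur shows no step beyond the scatter. Nothing offered in this account bears on why the two compounds read as they do.

From the compounds shown here alone, whether a carboxylic acid, an amine or a longer chain at this place would also stay within the scatter of compound 1 remains open. Going by these compounds, it is equally open whether the same ring exchange would read alike on a different core.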